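The compounds below may be only part of what the source reports. "The series", "measured", "known", "first", "only" and "open" are said of these compounds alone.

Measured compounds:

Compound 1, `CCO/N=C(\CCN1CCN(c2cccc(OCC)c2)CC1)c1ccccc1`, in a functional assay on HEK293 cells with D(4) dopamine receptor (Homo sapiens) as the target, read by FLIPR (a lower number here means a smaller maximal response, a higher number a larger maximal response), gives 84%.
Compound 2, `CCO/N=C(\CCN1CCN(c2ncccc2C#N)CC1)c1ccccc1`, gives 64%.
Compound 3, `CCO/N=C(\CCN1CCN(c2ncccc2C)CC1)c1ccccc1`, gives 49%.

Among these three, compound 3 stands lowest. Its nearest neighbour is compound 2, the gap being a number 15 percentage points lower from compound 2 to compound 3 (beyond the scatter), and the furthest is compound 1, with a number 35 percentage points lower from compound 1 to compound 3 (beyond the scatter). The third measured step, a number 20 percentage points lower from compound 1 to compound 2 (beyond the scatter), likewise shows that putting a six-membered heteroaryl in place of the 3-ethoxyphenyl on the ring amine nitrogen lowers the maximal response.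

Compound 4, `CCO/N=C(\CCN1CCN(c2nccs2)CC1)c1ccccc1`, differs from compound 3 in one place: 1,3-thiazol-2-yl in place of 3-methylpyridin-2-yl on an amine nitrogen in a ring. Among the compounds with values here, no measured step involves a five-membered ring on that nitrogen, so the three steps bear on this change only indirectly. They show that the group on this nitrogen moves the maximal response in this assay by modest to large amounts, and that a substituent on the heteroaryl matters, as compound 2 against compound 3 shows. The direction for a 1,3-thiazol-2-yl is not indicated by any step. Compound 4 is therefore expected to give about 52%, that is a step of a number 3 percentage points higher from compound 3 to compound 4 (within the scatter), within a range of 30% to 75%.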

Compound 4, largest response reached (reported as efficacy), in percent of the reference or control that the assay uses: 72%
Beside the measured number, compound 4's estimate is 20 percentage points below it; the range from low to high includes it.
By their numbers in this assay, from the lowest: compound 3; then compounds 2 and 4 (each within the scatter of the next); then compound 1.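

Within this assay the group on the amine nitrogen in a ring need not be six-membered to keep a sizeable response, as the change to 1,3-thiazol-2-yl gives a number 23 percentage points higher from compound 3 to compound 4 (beyond the scatter) and so moves the maximal response back up from the level of the 3-methylpyridin-2-yl. Against the substituted pyridine carrying the nitrile, the same change gives a number 8 percentage points higher from compound 2 to compound 4 (within the scatter) and so sets no order between those two groups, which leaves the 3-methylpyridin-2-yl clearly lowest among the three heteroaryl groups shown. Against the 3-ethoxyphenyl, the change still gives a number 12 percentage points lower from compound 1 to compound 4 (beyond the scatter) and so the five-membered aromatic ring with 2 hetero atoms does not reach the level of the phenyl compound.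

Nothing given here accounts for these differences. The compounds shown leave open whether the response follows ring size, the hetero atoms or the ring substituent, as the 1,3-thiazol-2-yl carries no substituent while both pyridines carry one, and they do not show how an unsubstituted pyridin-2-yl or a 1,3-thiazol-2-yl bearing a methyl or an amine would stand.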